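Moving a methyl on the sulfonyl aryl group

The source may report more compounds than this note shows. Statements on the series, on what has been measured and on what is new or still open speak of the compounds shown alone.

Compound 3 `Cc1cc(C)cc(S(=O)(=O)c2cnc3ccc(F)cc3c2N2CCC(C)CC2)c1` gives 83% in an assay on isolated protein for displacement of a labelled ligand from metabotropic glutamate receptor 5 (Homo sapiens), with a stated time of 60 min, tested at 1 uM (a lower number here means less inhibition, a higher number more inhibition at the concentration tested (going by the name of the read-out)), the second highest of the three numbers here, though both of its steps to the others lie within the scatter. Compound 1 `COc1ccc(S(=O)(=O)c2cnc3ccc(F)cc3c2N2CCC(C)CC2)cc1` gives 85% in this assay and compound 2 `CC1CCN(c2c(S(=O)(=O)c3cccc(F)c3)cnc3ccc(F)cc23)CC1` gives 76%; the steps of a number 2 percentage points lower from compound 1 to compound 3 (within the scatter), a number 7 percentage points higher from compound 2 to compound 3 (within the scatter) and a number 9 percentage points lower from compound 1 to compound 2 (within the scatter) all stay within the scatter. Compound 4 `Cc1ccc(S(=O)(=O)c2cnc3ccc(F)cc3c2N2CCC(C)CC2)cc1C` differs from compound 3 by 3,4-dimethylphenyl in place of 3,5-dimethylphenyl on a sulfonyl sulfur. Every measured step exchanged one aryl group for another on the sulfonyl sulfur without moving the number beyond the scatter, so no step beyond the scatter is expected here either. Compound 4 is therefore estimated at 83% in this assay, between 70% and 93%. This estimate means an expected step of no change at the digits printed from compound 3 to compound 4 (within the scatter).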

Compound 4, a percentage reported as inhibition, at one concentration (the size of the read-out at that concentration, not a potency): 92%
Compound 4: middle estimate off by 9 percentage points, on the low side, and the stated range covers the measured number.
By their numbers in this assay, from the lowest: compounds 2, 3, 1 and 4 (each within the scatter of the next, the first and the last beyond it).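

Moving one methyl, from 3,5-dimethylphenyl to 3,4-dimethylphenyl on the sulfonyl sulfur, gives a number 9 percentage points higher from compound 3 to compound 4 (within the scatter) in this assay, and the exchange for 4-methoxyphenyl gives a number 7 percentage points higher from compound 1 to compound 4 (within the scatter). Among these compounds, only a number 16 percentage points higher from compound 2 to compound 4 (beyond the scatter) passes the scatter, the first step at this position to do so, which shows that the aryl group here can bear on the number, if modestly. No measurement at hand accounts for this step. Open, on these data alone, is how a pyridyl or a benzyl group on the sulfonyl sulfur would read, or a single methyl on the phenyl. These single-concentration numbers also leave potency unsettled.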